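The source may hold more compounds than are shown below. What is called first, only, known or untested is meant among the compounds shown, and "the series" means these compounds.

Measured in a functional assay on SiHa cells (Homo sapiens) for inhibition, read by sulforhodamine B assay; on this read-out lower numbers stand for stronger inhibition of growth and higher numbers for weaker inhibition of growth:
- compound 1 `COc1ccc(-c2ccc(-c3ccc(-c4nc5cc(C)ccc5[nH]4)cc3)cc2)cc1OC`: 3510 nM
- compound 2 `Cc1ccc2[nH]c(-c3ccc(-c4ccc(-c5ccc(F)cc5)cc4)cc3)nc2c1`: 41000 nM

Compound 2 holds the higher of the two numbers. Compound 3 `Cc1ccc2[nH]c(-c3ccc(-c4ccc(-c5ccc(O)cc5)cc4)cc3)nc2c1` differs from it by hydroxy in place of fluoro on an aromatic carbon, para to a large group. Within the data shown here, one measured step bears on this, the large 12-fold higher number from compound 1 to compound 2 (1.07 log units; beyond the scatter), which also removes 3,4-dimethoxyphenyl rather than a hydroxy-bearing group, so the evidence is indirect. A lower number in this assay is expected, with an estimated 4.6-fold lower number from compound 2 to compound 3 (0.66 log units; beyond the scatter). The expected value for compound 3 is 9000 nM, with an estimated range of 2500 nM to 32000 nM.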

Compound 3, concentration for 50% growth inhibition: 33500 nM
Estimate against measurement, compound 3: 3.7-fold (0.57 log units) below, and the stated range ends below it.
By their numbers in this assay, from the lowest: compound 1; then compounds 3 and 2 (each within the scatter of the next).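

Hydroxy in place of fluoro at this position, para to a large group, gives a 1.2-fold lower number from compound 2 to compound 3 (0.09 log units; within the scatter) in this assay and so makes no difference beyond the scatter, despite the hydrogen-bond donor and acceptor it brings. The 4-hydroxyphenyl group also leaves a 9.5-fold higher number from compound 1 to compound 3 (0.98 log units; beyond the scatter) and does not close the gap to the 3,4-dimethoxyphenyl group. No measurement on hand accounts for either result.

Going by these compounds, whether an amine or a carboxylic acid at this position would separate from fluoro and hydroxy remains open. Also open, on these data alone, is whether a single methoxy group would match compound 1.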